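The compounds below may be only part of what the source reports. "The series", "measured", "known", "first", "only" and "open" are said of these compounds alone.

Of the compounds shown here, three have been measured in an assay on HEK293 cells for positive allosteric modulation of metabotropic glutamate receptor 3 (Rattus norvegicus), read by thallium flux, with a stated time of 2.5 min; a higher number here means a larger maximal response, a lower number a smaller maximal response. Compound 3, `Cc1c(OCCCCOc2ccccc2C(=O)O)ccc(C(=O)CC(C)C)c1O`, gives 28.1% in this assay, the second highest of the three numbers. Its nearest neighbour is compound 1, `Cc1c(OCCCCOc2ccccc2C(=O)O)ccc(C(=O)CC2CCCC2)c1C`, which gives 28% in this assay, a number within the usual scatter of that of compound 3, so the two cannot be told apart. Furthest from it is compound 2, `Cc1c(OCCCCOc2ccc(C(=O)CC(C)(C)C)c(O)c2C)cccc1C(=O)O`, which gives 109% in this assay, a gap beyond the scatter.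

Compound 4, `Cc1c(OCCCCOc2ccc(C(=O)O)cc2)ccc(C(=O)CC(C)C)c1O`, is not yet measured in this assay. It differs from compound 3 in one place: 4-carboxyphenyl in place of 2-carboxyphenyl on an oxygen on a saturated carbon. Among the compounds with values here, no pair of measured compounds differs in one place only, so no measured step guides the change. Compound 2 shows that a different placing of the carboxylic acid can go with a much larger maximal response, while compound 1 shows that the ketone side chain alone does not separate the low numbers. The step is therefore expected to be upward by a modest amount, and the expectation for compound 4 is 45% (range 20% to 80%), an expected step of a number 16.9 percentage points higher from compound 3 to compound 4 (beyond the scatter).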

Compound 4, largest response reached (reported as percent of maximum), in percent of the reference or control that the assay uses: 51.9%
For compound 4 the middle estimate is 6.9 percentage points below the measured one; measured number inside the range.
By their numbers in this assay, from the lowest: compounds 1 and 3 (each within the scatter of the next); then compound 4; then compound 2.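

In this assay, within the data shown here, 4-carboxyphenyl in place of 2-carboxyphenyl on an oxygen on a saturated carbon gives the first step that can be read at a single place, a number 23.8 percentage points higher from compound 3 to compound 4 (beyond the scatter). The two compounds have the same atoms joined differently, so the placing of the carboxylic acid on this ring alone is enough to change the maximal response in this series. No measurement shown here explains why the response changes with this placing.

Going by these compounds, it remains open whether the same change would raise the response on the core of compound 1, which differs from compound 3 elsewhere. Also open, on these data alone, is how the response would change with an amide or a methyl ester in place of the carboxylic acid, or with a longer chain carrying the ring.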